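Amide in place of ether at the saturated ring carbon

A few compounds are considered here, and "the series" means these few. Any claim that something is new, unique, unknown or untested is made for them only; others in the source may bear on it.

The set is followed in a functional assay on HEK293 cells for agonist activity at G-protein coupled receptor 39 (Homo sapiens), read by scintillation proximity assay and inositol phosphate accumulation, with a stated time of 75 min; a lower number here means that less compound is needed, a higher number that more compound is needed for the effect. Compound 1 `Cc1nn(-c2ncnc3nc[nH]c23)c2c1C(OC1CCCC1)CC(=O)N2` gives 62 nM in this assay. Among the measured compounds shown here, compound 2 `Cc1nn(-c2ncnc3nc[nH]c23)c2c1C(OCCc1ccccc1)CC(=O)N2` gives 40 nM in this assay, and the step of a 1.6-fold lower number from compound 1 to compound 2 (0.19 log units; within the scatter) is the only measured step between neighbours in the set. Compound 3 `Cc1cc(C)nc(-n2nc(C)c3c2NC(=O)CC3c2ccc(F)cc2F)n1` belongs to a different branch; in this assay compound 3 reaches only a limit, > 10000 nM, and not a number. Compound 2 therefore holds the lowest of the two numbers shown, with compound 1 within the scatter of it, while one further value sits at a limit (the limit of > 10000 nM in this assay, at which 1 of the 3 values shown sits).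

Compound 4 `Cc1nn(-c2ncnc3nc[nH]c23)c2c1C(NC(=O)Cc1cccs1)CC(=O)N2` differs from compound 2 as follows: (((thiophen-2-yl)methyl)carbonyl)amino in place of phenethyloxy on a saturated ring carbon. For the measured compounds named here, the single measured step, which exchanged one group for another on the same oxygen, stayed within the scatter; no measured step exchanges the oxygen itself for an amide, so the data bear only weakly on this change. A modest shift with no firm direction is expected. Compound 4 is estimated at 150 nM, with a range from 40 nM to 600 nM. The expected step is a 3.8-fold higher number from compound 2 to compound 4 (0.57 log units; beyond the scatter).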

Compound 4, half-maximal effective concentration: 244 nM
Compound 4: the middle estimate sits 1.6-fold (0.21 log units) below what was measured; low and high end bracket the measured number.
By their numbers in this assay, from the lowest: compounds 2 and 1 (each within the scatter of the next); then compound 4. At a limit, above all of these: compound 3.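

Among the compounds shown here, the ether oxygen at this saturated ring carbon can be exchanged for an amide nitrogen with a number still obtained, but this gives the first steps at the position that lie beyond the scatter: a 6.1-fold higher number from compound 2 to compound 4 (0.79 log units; beyond the scatter), and a 3.9-fold higher number from compound 1 to compound 4 (0.59 log units; beyond the scatter), both modest. The earlier exchange on the oxygen, a 1.6-fold lower number from compound 1 to compound 2 (0.19 log units; within the scatter), stayed within the scatter, and the new group enters with the same count of heavy atoms as phenethyloxy, while adding a hydrogen-bond donor and a carbonyl. Nothing measured here explains either step.

The amide and the thiophene ring enter together, so their shares of the step stay unseparated. A (phenylacetyl)amino group or a 2-(thiophen-2-yl)ethoxy ether at this carbon would divide them, and a free amine there remains an open case.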